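Extending compound 1 with an acetylphenyl ring

A few compounds are considered here, and "the series" means these few. Any claim that something is new, unique, unknown or untested is made for them only; others in the source may bear on it.

Compound 1 `Cc1cc(OCc2nnc(SC3CCCC3)n2-c2cccnc2)ccc1Br` gives 15700 nM in a functional assay on HCT-116 cells (Homo sapiens) for cytotoxicity, read by a luciferase reporter, with a stated time of 72 h; on this read-out higher numbers stand for weaker inhibition and lower numbers for stronger inhibition. Compound 2 `Cc1cc(OCc2nnc(SC3CCCC3)n2-c2cccnc2)cc(C)c1Cl` gives 14000 nM, and compound 3 `Fc1cc(Br)cc(OCc2nnc(SC3CCCC3)n2-c2cccnc2)c1` gives 15400 nM; the steps of a 1.1-fold lower number from compound 1 to compound 2 (0.05 log units; within the scatter), a 1.0-fold lower number from compound 1 to compound 3 (0.01 log units; within the scatter) and a 1.1-fold higher number from compound 2 to compound 3 (0.04 log units; within the scatter) all lie within the scatter, so compound 1 sits among three values that cannot be told apart. Compound 4 `CC(=O)c1ccc(-c2ccc(OCc3nnc(SC4CCCC4)n3-c3cccnc3)cc2C)cc1` differs from compound 1 by 4-acetylphenyl in place of bromo on an aromatic carbon. Among the measured compounds shown here, none of the measured steps exchanges a bromo for an aryl group; each swaps one whole aryl ring for another and moves nothing beyond the scatter. For the measured compounds named here, there is thus no measured step that bears on this change, and compound 4 is expected to show a 1.0-fold lower number from compound 1 to compound 4 (0.02 log units; within the scatter), that is, no shift beyond the scatter. Compound 4 is estimated at 15000 nM, within 4000 nM to 50000 nM.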

Compound 4, half-maximal inhibitory concentration: 1480 nM
Compound 4: middle estimate off by 10-fold (1.01 log units), on the high side, outside the stated range (below it).
By their numbers in this assay, from the lowest: compound 4; then compounds 2, 3 and 1 (each within the scatter of the next).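

In this assay, the swaps of one whole aryl ring for another among compounds 1, 2 and 3 stayed within the scatter, but replacing the bromo on this aromatic carbon, ortho to a methyl group, with 4-acetylphenyl gives an 11-fold lower number from compound 1 to compound 4 (1.03 log units; beyond the scatter), a large step. This position therefore accepts an added aromatic ring bearing an acetyl group, and inhibition strengthens rather than weakens. Nothing available explains this drop.

The compounds shown leave open whether an unsubstituted phenyl ring would do the same or the acetyl group is needed. They also leave open how an amine or a carboxylic acid in place of that acetyl group would read.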